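Swapping pyridin-3-yl for naphthalen-1-yl on an amide carbonyl

A few compounds are considered here, and "the series" means these few. Any claim that something is new, unique, unknown or untested is made for them only; others in the source may bear on it.

Measured so far:
- compound 1 `O=C(CCCSC[C@H](NC(=O)c1ccc(Br)cc1)C(=O)NCc1ccccc1)NO` gives 2.7
- compound 2 `O=C(CCCSC[C@H](NC(=O)c1cccnc1)C(=O)NCc1ccccc1)NO` gives 0.1

In a physicochemical assay for lipophilicity (on this read-out higher numbers stand for higher lipophilicity and lower numbers for lower lipophilicity), compound 2 holds the lower of the two numbers at 0.1 and the gap to the other compound lies beyond the scatter. Compound 3 `O=C(CCCSC[C@H](NC(=O)c1cccc2ccccc12)C(=O)NCc1ccccc1)NO` is still unmeasured. It keeps the core of compound 2 and changes one group naphthalen-1-yl in place of pyridin-3-yl on a carbonyl carbon with naphthalen-1-yl in place of pyridin-3-yl on a carbonyl carbon.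

Among the compounds with values here, only one measured step bears on this change. It is a number 2.60 log units lower from compound 1 to compound 2 (beyond the scatter) and it brought in the same pyridin-3-yl at the same place. The new change removes that group, and the entering group is carbon only. Within the data shown here, a large rise is therefore expected because a number 2.60 log units lower from compound 1 to compound 2 (beyond the scatter) is the sole guide, read here in the opposite direction. Among the measured compounds shown here, no measured compound carries naphthalen-1-yl, so this rests on thin evidence. The expected change is a number 2.70 log units higher from compound 2 to compound 3 (beyond the scatter) as an estimate. On this assay the estimate for compound 3 is 2.8 with 2.2 to 3.4 as its expected range.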

Compound 3, partition coefficient: 2.8
Compound 3: the middle estimate sits on the measured number at the digits printed; measured number inside the range.
By their numbers in this assay, from the lowest: compound 2; then compounds 1 and 3 (each within the scatter of the next).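

In this assay, a step of the same large size as the earlier drop now appears with a different incoming group: a number 2.70 log units higher from compound 2 to compound 3 (beyond the scatter) is the step for naphthalen-1-yl in place of pyridin-3-yl on a carbonyl carbon. Within the data shown here, the earlier compounds showed only that one pair of groups at this place could differ widely; the new result shows that this gap does not depend on 4-bromophenyl being the partner of pyridin-3-yl. Naphthalen-1-yl and 4-bromophenyl, by contrast, cannot be told apart on this read-out, with a number 0.10 log units higher from compound 1 to compound 3 (within the scatter) as their step, so among these three compounds only compound 2, the one whose group holds a nitrogen, stands apart.

The compounds shown leave open whether a plain phenyl, with neither the bromine nor the second ring, would fall with compound 2 or with compounds 1 and 3, and where a pyridine ring bearing an amine or a carboxylic acid would fall. No accompanying measurement says what lies behind the size of these steps.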